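This account rests on a few compounds, and the source may have more. Where it says the series, first, only, none or still open, it means among the compounds named here.

Working notes on the series in an ADME assay on the whole organism with Oryza sativa as the target, tested at 0.1 uM; a higher number here means a weaker effect of the compound at the concentration tested, a lower number a stronger effect.

Compound 3 `C[C@@H](NC(=O)Nc1cc(C(F)(F)F)cc(C(F)(F)F)c1)c1ccccc1` gives 100% in this assay. Compound 2 `C[C@H](NC(=O)Nc1cccc(C(F)(F)F)c1)c1ccccc1` gives 94%, which sits within the scatter of compound 3. Compound 1 `C[C@@H](NC(=O)Nc1cccc(C(F)(F)F)c1)c1ccccc1` gives 82%, a gap to compound 3 that lies beyond the scatter; the step of a number 18 percentage points higher from compound 1 to compound 3 (beyond the scatter) is the trifluoromethyl in place of hydrogen on an aromatic carbon.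

Compound 4 `C[C@H](NC(=O)Nc1cc(C(F)(F)F)cc(C(F)(F)F)c1)c1ccccc1` is the next target. Its difference from compound 3: the two compounds have the same atoms and bonds and differ only in configuration as drawn: 1 of 1 stereo elements differ; a stereocentre at a saturated chain carbon is drawn R in compound 3 and S in compound 4

For the measured compounds named here, one measured step bears directly on this change. The step of a number 12 percentage points higher from compound 1 to compound 2 (beyond the scatter) rests on the fact that compounds 1 and 2 differ only in the configuration as drawn and is of the same kind as the step to compound 4, an inversion at the single saturated chain stereocentre. Taken alone it would point to a rise of similar size. Compound 3 already stands at the full read-out of the scale, so there is little room for a further number to rise, and any change is expected to stay within the scatter.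

Compound 4 is therefore expected to give 100% in this assay, with a range of 92% to 106%. The expected step of no change at the digits printed from compound 3 to compound 4 (within the scatter) is estimated not to exceed the scatter.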

Compound 4, a percentage reported as activity, at one concentration (the size of the read-out at that concentration, not a potency): 101%
Compound 4: middle estimate off by 1 percentage points, on the low side; measured number inside the range.
By their numbers in this assay, from the lowest: compound 1; then compounds 2, 3 and 4 (each within the scatter of the next).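

In this assay, the inversion at the saturated chain stereocentre can now be read on the core with the second trifluoromethyl, where it gives a number 1 percentage points higher from compound 3 to compound 4 (within the scatter), unlike the step of a number 12 percentage points higher from compound 1 to compound 2 (beyond the scatter) on the core of compound 1; the two comparisons are clean in that each pair holds configuration as its only difference: the fact that compounds 3 and 4 differ only in the configuration as drawn. The trifluoromethyl in place of hydrogen on an aromatic carbon can also now be read in the second configuration, as a number 7 percentage points higher from compound 2 to compound 4 (within the scatter), and this step does not differ meaningfully from its counterpart in the first configuration: the same change on two cores in this assay, a number 18 percentage points higher (beyond the scatter) from compound 1 to compound 3 and a number 7 percentage points higher (within the scatter) from compound 2 to compound 4, 11 percentage points apart, within the scatter of two such steps. Of the four compounds, only compound 1 has a configuration effect and a trifluoromethyl effect printed as beyond the scatter, so configuration separates the pair on its core but not the pair with the second trifluoromethyl.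

From the compounds shown here alone, whether a nitrile or a carboxylic acid in place of the second trifluoromethyl, or a longer chain at the stereocentre, would move the read-out in either configuration remains open. All four numbers come from a single concentration, so they give no potency for either configuration.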